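A few compounds are considered here, and "the series" means these few. Any claim that something is new, unique, unknown or untested is made for them only; others in the source may bear on it.

For the measured compounds named here, only two compounds have been read in a functional assay on KYSE-70 cells for antiproliferative activity against KYSE-70 cell line (Homo sapiens), read by MTT assay, with a stated time of 72 h (a lower number here means a stronger inhibitor, a higher number a weaker inhibitor), and neither gave a number. Compound 1 `O=C(Nc1cc(F)cc(F)c1)c1cc(=O)[nH]c2cc(O)ccc12` reads > 20000 nM, which is a limit of the assay. Compound 2 `CC(C)(C)c1ccc(-c2ccc3c(C(=O)Nc4cccc(F)c4)cc(=O)[nH]c3c2)cc1` reads > 20000 nM, which is also a limit. Both therefore rest at the limit of > 20000 nM in this assay, at which 2 of the 2 values shown sit, and compound 2 has no measured value to rank it by.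

Compound 3 `O=C(Nc1cccc(F)c1)c1cc(=O)[nH]c2cc(-c3ccccc3F)ccc12` differs from compound 2 in one place: on an aromatic carbon, 2-fluorophenyl stands in place of 4-(tert-butyl)phenyl (2-fluorophenyl in place of 4-(tert-butyl)phenyl on an aromatic carbon). Going by the values given here, no measured step is available to size this change, so no shift beyond the scatter is expected in this assay. The expected a number no higher from compound 2 to compound 3 (the limit leaves the size open) is an estimate with no favoured direction. Compound 3 is estimated at 20000 nM. Its expected range runs from 8000 nM to 40000 nM, and a further reading at the limit would be the likeliest outcome.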

Compound 3, half-maximal inhibitory concentration: > 20000 nM
Compound 3 gave a limit, no number; the forecaster's own chance of this, stated with the estimate: 65%; the middle value lies on the limit itself.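

In this assay, for the compounds shown here, compound 3 gives > 20000 nM, which is a limit, and compound 2 also rests on a limit, so no step from one to the other can be read. The compounds shown leave open whether any change to the shared core gives a measured number: the limit of > 20000 nM in this assay, at which 3 of the 3 values shown sit.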